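The compounds below may be only part of what the source reports. "The series", "measured", "known", "first", "only" and "open" are said of these compounds alone.

Measured so far in an ADME assay on HEK293 cells (Homo sapiens) for cytotoxicity, read by MTT assay, with a stated time of 48 h; on this read-out lower numbers stand for stronger inhibition and higher numbers for weaker inhibition:
compound 1, `CS(=O)(=O)Nc1ccc(NC(=O)c2ccc(C#N)cc2)cc1F`, > 250000 nM
compound 2, `CS(=O)(=O)Nc1ccc(NC(=O)c2cccc(C(F)(F)F)c2)cc1F`, > 250000 nM
compound 3, `CCS(=O)(=O)Nc1ccc(NC(=O)c2ccc(C#N)cc2)cc1F`, 26400 nM

The value of compound 1 in this assay is a limit, not a number. The value of compound 2 is likewise a limit. Compound 3 alone gives a number. From compound 1 to compound 3 the change is methyl in place of hydrogen on a saturated chain carbon bound to a sulfonyl sulfur, and it gives an at least 9.4-fold lower number from compound 1 to compound 3 (0.97 log units; beyond the scatter); the step is bounded by the limit of > 250000 nM in this assay, at which 2 of the 3 values shown sit, at which compound 1 sits.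

Compound 4, `CCS(=O)(=O)Nc1ccc(NC(=O)c2cccc(C(F)(F)F)c2)cc1F`, stands to compound 2 as compound 3 stands to compound 1: the change is methyl in place of hydrogen on a saturated chain carbon bound to a sulfonyl sulfur, the same change at the same place. How the core of compound 2 differs from the core of compound 1 is not broken down here.

On these data alone, since the earlier step rests on a limit, its true size is unknown, so the expectation for compound 4 is wide. Compound 4 is estimated at 40000 nM, between 10000 nM and 250000 nM. The estimated step is an at least 6.2-fold lower number from compound 2 to compound 4 (0.79 log units; beyond the scatter), which is expected to resemble the earlier one.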

Compound 4, half-maximal inhibitory concentration: 94800 nM
Beside the measured number, compound 4's estimate is 2.4-fold (0.37 log units) below it; the range from low to high includes it.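

In this assay the change from methylsulfonyl to ethylsulfonyl carries over to the core of compound 2, giving an at least 2.6-fold lower number from compound 2 to compound 4 (0.42 log units; beyond the scatter). The direction is thus the same on both cores shown, but this does not establish that the change has the same size on each: the same change on two cores in this assay, an at least 9.4-fold lower number (0.97 log units; beyond the scatter) from compound 1 to compound 3 and an at least 2.6-fold lower number (0.42 log units; beyond the scatter) from compound 2 to compound 4; the limit leaves it open whether they differ Both steps start from the same limit of the assay, so their true sizes stay unknown: the limit of > 250000 nM in this assay, at which 2 of the 4 values shown sit.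

The compounds shown leave open whether a longer chain on the sulfonyl, such as propyl or butyl, would continue this trend. They also leave open whether the change would carry over to a core bearing an amine or a carboxylic acid in place of nitrile or trifluoromethyl.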